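The source may hold more compounds than are shown below. What is called first, only, known or untested is meant among the compounds shown, and "the series" means these compounds.

Three compounds with a shared core have numbers in an in vitro ADME assay on microsomes from liver (Homo sapiens) for metabolic stability, using NADPH; a lower number here means slower removal, a higher number faster removal of the compound. Compound 1 `COc1ccc(OC(F)(F)F)cc1Cn1c(C(=O)NCC(C)(C)CO)cc2cc(C#N)ccc21` gives 69 mL.min-1.g-1, compound 2 `CCOc1ccc(OC(F)(F)F)cc1Cn1c(C(=O)NCC(C)(C)CO)cc2cc(C#N)ccc21` gives 103 mL.min-1.g-1, and compound 3 `CC(C)(CO)CNC(=O)c1cc2cc(C#N)ccc2n1Cc1cc(Cl)cc(Cl)c1` gives 103 mL.min-1.g-1. Compound 3 is level with compound 2, and all three values lie within the scatter of each other.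

Compound 4 `COc1ccc(Cl)cc1Cn1c(C(=O)NCC(C)(C)CO)cc2cc(C#N)ccc21` differs from compound 3 at one place: 5-chloro-2-methoxyphenyl in place of 3,5-dichlorophenyl on a saturated chain carbon bound to an aromatic nitrogen. In words, 5-chloro-2-methoxyphenyl stands in place of 3,5-dichlorophenyl on a saturated chain carbon bound to an aromatic nitrogen.

Within the data shown here, no measured step covers this exchange. Among the measured compounds shown here, the only measured step, a 1.5-fold higher number from compound 1 to compound 2 (0.17 log units; within the scatter), concerns the chain on the oxygen and bears on it only indirectly. Compound 1 also carries a methoxy group, and its 69 mL.min-1.g-1 serves as the closest guide.

The expected step is a 1.3-fold lower number from compound 3 to compound 4 (0.11 log units; within the scatter), which means no change beyond the scatter. For compound 4 the estimated value in this assay is 80 mL.min-1.g-1, with an expected range of 40 mL.min-1.g-1 to 150 mL.min-1.g-1.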

Compound 4, intrinsic clearance in microsomes: 83 mL.min-1.g-1
Compound 4: the middle estimate sits 1.0-fold (0.02 log units) below what was measured; measured number inside the range.
By their numbers in this assay, from the lowest: compounds 1, 4, 2 and 3 (each within the scatter of the next).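

Putting 5-chloro-2-methoxyphenyl in place of 3,5-dichlorophenyl on a saturated chain carbon bound to an aromatic nitrogen gives, in this assay, a 1.2-fold lower number from compound 3 to compound 4 (0.09 log units; within the scatter), so this exchange of the whole aryl group stays inside the scatter. Chloro in place of trifluoromethoxy on an aromatic carbon gives, in this assay, a 1.2-fold higher number from compound 1 to compound 4 (0.08 log units; within the scatter), which also stays inside the scatter, so neither change to this aryl group separates the compounds. Nothing available explains either reading.

All four numbers lie within the scatter of the next, so the compounds shown do not reveal what, if anything, at this position would move the number beyond it. From the compounds shown here alone, whether an amine or a carboxylic acid in place of the chloro would do so remains open.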